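Pyridin-4-yl for 3,4,5-trimethoxyphenyl: working notes on compound 4

The compounds below may be only part of what the source reports. "The series", "measured", "known", "first", "only" and "open" are said of these compounds alone.

Compound 1 `O=C1/C(=C\c2ccccc2)c2c(ncn2COCc2ccccc2)CCN1Cc1ccccc1` gives 9900 nM in a functional assay on A549 cells (Homo sapiens) for inhibition, read by MTT assay, with a stated time of 72 h; a higher number here means a weaker inhibitor, a lower number a stronger inhibitor. Compound 2 `Cc1cc(C)cc(CN2CCc3ncn(COCc4ccccc4)c3/C(=C/c3ccccc3)C2=O)c1` gives 22500 nM and stands apart at a higher number (a 2.3-fold higher number from compound 1 to compound 2 (0.36 log units; beyond the scatter)), but that step lies at the other phenyl place. Compound 3 `COc1cc(/C=C2\C(=O)N(Cc3ccccc3)CCc3ncn(COCc4ccccc4)c32)cc(OC)c1OC` gives 8560 nM and cannot be separated from compound 1, so it shares the low end of these numbers with that compound.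

Compound 4 `O=C1/C(=C\c2ccncc2)c2c(ncn2COCc2ccccc2)CCN1Cc1ccccc1` has pyridin-4-yl in place of 3,4,5-trimethoxyphenyl on a double-bonded chain carbon bound to a double-bonded ring carbon. The step that bears on this place is the exchange of phenyl for 3,4,5-trimethoxyphenyl (a 1.2-fold lower number from compound 1 to compound 3 (0.06 log units; within the scatter)), which stayed within the scatter. No ring with a hetero atom has been measured at this place, so the expectation is uncertain. In this assay no clear step beyond the scatter is expected, with a slight drift to a higher number as the estimated outcome (a 1.4-fold higher number from compound 3 to compound 4 (0.15 log units; within the scatter)). For compound 4 the estimated value is 12000 nM (expected range 5000 nM to 30000 nM).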

Compound 4, half-maximal inhibitory concentration: 36000 nM
Estimate against measurement, compound 4: 3.0-fold (0.48 log units) below; measured number above the stated range.
By their numbers in this assay, from the lowest: compounds 3 and 1 (each within the scatter of the next); then compounds 2 and 4 (each within the scatter of the next).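

At the double-bonded chain carbon bound to a double-bonded ring carbon, the ring now matters in this assay, with pyridin-4-yl giving a 4.2-fold higher number from compound 3 to compound 4 (0.62 log units; beyond the scatter) and, against the plain phenyl, a 3.6-fold higher number from compound 1 to compound 4 (0.56 log units; beyond the scatter) as well. The earlier exchange of phenyl for 3,4,5-trimethoxyphenyl stayed within the scatter, so this place had looked tolerant, and compound 1 shows that losing the methoxy groups alone does not reproduce the new step. Nothing available explains the shift.

The compounds shown leave open whether the step follows the ring nitrogen as such or its location in the ring, which a pyridin-3-yl or pyridin-2-yl group would address. They also leave open how a phenyl ring carrying an amine or a carboxylic acid would behave at this place.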